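Working notes on a small antiproliferative series

A few compounds are considered here, and "the series" means these few. Any claim that something is new, unique, unknown or untested is made for them only; others in the source may bear on it.

Measured so far:
compound 1, `CSc1cnc2ccccc2c1[Se]CC#CCOC(=O)c1ccc(C(=O)O)cc1`: in a functional assay on T47D cells (Homo sapiens) for antiproliferative activity, with a stated time of 72 h (on this read-out higher numbers stand for weaker inhibition and lower numbers for stronger inhibition), compound 1 gives 3.2 ug/mL
compound 2, `ClCC#CCSc1cnc2ccccc2c1Cl`: compound 2 gives 3.2 ug/mL
compound 3, `OCC#CCSc1cnc2ccccc2c1SCC#CCCl`: compound 3 gives 5.3 ug/mL

Compound 1 stands level with compound 2 at the digits shown, and the two together hold the lowest of the three numbers; compound 3 sits within the scatter of compound 1, so no order among the three can be read from these values.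

Compound 4 `CSc1cnc2ccccc2c1[Se]CC#CCOC(=O)/C=C/c1ccccc1` has not yet been measured. It differs from compound 1 in one place:

2-phenylethenyl in place of 4-carboxyphenyl on a carbonyl carbon

Going by the values given here, no pair of measured compounds shows a step of this kind, so nothing beyond the value of compound 1 anchors the expectation. The step is expected to stay small, in no clear direction beyond the usual scatter. Compound 4 is therefore expected to give about 2.8 ug/mL, within a range of 1.1 ug/mL to 7 ug/mL. The step this estimate implies, a 1.1-fold lower number from compound 1 to compound 4 (0.06 log units; within the scatter), is expected to lie within the scatter.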

Compound 4, concentration for 50% inhibition: 4.3 ug/mL
Beside the measured number, compound 4's estimate is 1.5-fold (0.19 log units) below it; the range from low to high includes it.
By their numbers in this assay, from the lowest: compounds 1, 2, 4 and 3 (each within the scatter of the next).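

In this assay, 2-phenylethenyl in place of 4-carboxyphenyl on a carbonyl carbon gives a 1.3-fold higher number from compound 1 to compound 4 (0.13 log units; within the scatter), the first step read at this position. The hydrogen-bond donor and acceptor counted on 4-carboxyphenyl can therefore be lost here, along with both oxygens, without a readable change in this pair. Nothing available bears on the reason for this result.

On these data alone, whether any group at this position can move the number beyond the scatter remains open. A basic amine or a short alkyl chain on this carbonyl carbon would test that.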